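Methyl and amide changes on a shared thiazole-fused core

The compounds below may be only part of what the source reports. "The series", "measured", "known", "first", "only" and "open" are said of these compounds alone.

Measured compounds:
compound 1 `C=C(Br)C(=O)Nc1cccc(-c2cn3nc(-c4ccccc4)sc3n2)c1`, 1400 nM in a functional assay on HeLa cells (Homo sapiens) for inhibition, read by cell counting, with a stated time of 4 days; a lower number here means a stronger inhibitor, a higher number a weaker inhibitor
compound 2 `C=C(Br)C(=O)Nc1cccc(-c2cn3nc(-c4ccc(C)cc4)sc3n2)c1`, 2000 nM in this assay
compound 3 `Nc1cccc(-c2cn3nc(-c4ccccc4)sc3n2)c1`, 26000 nM in this assay

Compound 2 differs from compound 1 by methyl in place of hydrogen on an aromatic carbon; this gave a 1.4-fold higher number from compound 1 to compound 2 (0.15 log units; within the scatter). Compound 3 differs from compound 1 by hydrogen in place of (1-bromoethenyl)carbonyl on a nitrogen on an aromatic ring; this gave a 19-fold higher number from compound 1 to compound 3 (1.27 log units; beyond the scatter). Compound 4 `Cc1ccc(-c2nn3cc(-c4cccc(N)c4)nc3s2)cc1` is not yet measured. It differs from compound 3 by methyl in place of hydrogen on an aromatic carbon, the same change as that from compound 1 to compound 2, made on the core of compound 3 rather than that of compound 1. The step in this assay is expected to be about a 1.2-fold higher number from compound 3 to compound 4 (0.09 log units; within the scatter) because the same change gave only a 1.4-fold higher number from compound 1 to compound 2 (0.15 log units; within the scatter). For compound 4 the estimate is therefore 32000 nM, between 14000 nM and 70000 nM.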

Compound 4, half-maximal inhibitory concentration: 8900 nM
Estimate against measurement, compound 4: 3.6-fold (0.56 log units) above; measured number below the stated range.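

In this assay, the phenyl to 4-methylphenyl change does not carry over from one core to the other, as a 2.9-fold lower number from compound 3 to compound 4 (0.47 log units; beyond the scatter) stands against the earlier step: the same change on two cores in this assay, a 1.4-fold higher number (0.15 log units; within the scatter) from compound 1 to compound 2 and a 2.9-fold lower number (0.47 log units; beyond the scatter) from compound 3 to compound 4, 4.2-fold (0.62 log units) apart, beyond the scatter of two such steps
Loss of the (1-bromoethenyl)carbonyl group raises the number on both cores, with a 4.5-fold higher number from compound 2 to compound 4 (0.65 log units; beyond the scatter), but the size of the step is not the same: the same change on two cores in this assay, a 19-fold higher number (1.27 log units; beyond the scatter) from compound 1 to compound 3 and a 4.5-fold higher number (0.65 log units; beyond the scatter) from compound 2 to compound 4, 4.2-fold (0.62 log units) apart, beyond the scatter of two such steps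
Both gaps come from the same four compounds and are one observation, which shows that the two changes are not independent here but gives no reason for this and no rule for other cores.

The compounds shown leave open whether a chlorine or a methoxy group in place of the methyl follows the same course on each core. They also leave open how a plain acetyl group on the nitrogen compares with the (1-bromoethenyl)carbonyl group.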